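A few compounds are considered here, and "the series" means these few. Any claim that something is new, unique, unknown or untested is made for them only; others in the source may bear on it.

Compound 1 `O=C(O)CNC(=O)c1c(O)c2c(n(Cc3ccc(Cl)cc3)c1=O)CCOC2` gives 5.9 nM in an assay on Sf9 cells for inhibition of prolyl hydroxylase EGLN2 (Homo sapiens), read by TR-FRET, with stated times of 30 min and 2 h; on this read-out lower numbers stand for stronger inhibition and higher numbers for weaker inhibition. Compound 2 `O=C(O)CNC(=O)c1c(O)c2c(n(Cc3ccc(C(F)(F)F)cc3)c1=O)COC2` gives 3.6 nM in this assay, and compound 3 `O=C(O)CNC(=O)c1c(O)c2c(n(Cc3ccc(F)cc3F)c1=O)COC2` gives 2.2 nM in this assay. Compound 3 has the lowest of the three numbers; its gap to compound 2 lies within the scatter, while its gap to compound 1 lies beyond it. Compound 4 `O=C(O)CNC(=O)c1c(O)c2c(n(Cc3cnc(C(F)(F)F)s3)c1=O)COC2` carries 2-(trifluoromethyl)-1,3-thiazol-5-yl in place of 2,4-difluorophenyl on a saturated chain carbon bound to an aromatic nitrogen. Because compound 1 gives 5.9 nM and compound 2 gives 3.6 nM with different groups on the saturated chain carbon bound to the aromatic nitrogen, the step from compound 3 to compound 4 is expected to be a 1.8-fold higher number from compound 3 to compound 4 (0.26 log units; within the scatter), not beyond the scatter in either direction. Compound 4 is therefore estimated at 4 nM in this assay, within a range from 1.5 nM to 12 nM.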

Compound 4, half-maximal inhibitory concentration: 2.4 nM
Compound 4: middle estimate off by 1.7-fold (0.22 log units), on the high side; measured number inside the range.
By their numbers in this assay, from the lowest: compounds 3, 4, 2 and 1 (each within the scatter of the next, the first and the last beyond it).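

Putting 2-(trifluoromethyl)-1,3-thiazol-5-yl in place of 2,4-difluorophenyl on a saturated chain carbon bound to an aromatic nitrogen gives a 1.1-fold higher number from compound 3 to compound 4 (0.04 log units; within the scatter) in this assay. This is the only pair shown that differs in one place, and it shows that a five-membered aromatic ring with 2 hetero atoms can stand there for a six-membered carbon ring with no step beyond the scatter. Nothing available accounts for this result. Open, as far as these compounds go, is whether a piperidine or a plain alkyl chain on that carbon would keep the number in this range, and whether the thiazole group behaves alike on the core of compound 1.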